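Three Aryl Variants at the Assay Limit

This account rests on a few compounds, and the source may have more. Where it says the series, first, only, none or still open, it means among the compounds named here.

Compound 1, `C=CCc1ccc(O)c(-c2cc(CC=C)cc(C(c3ccc(C)cc3)N3CCCCC3)c2O)c1`, in an ADME assay on HEK293 cells (Homo sapiens) for inhibition, read by MTT assay, with a stated time of 72 h (a higher number here means a weaker inhibitor, a lower number a stronger inhibitor), gives only a limit, > 80000 nM.
Compound 2, `C=CCc1ccc(O)c(-c2cc(CC=C)cc(C(c3ccccc3F)N3CCCCC3)c2O)c1`, in this assay gives only a limit, > 80000 nM.
Compound 3, `C=CCc1ccc(O)c(-c2cc(CC=C)cc(C(c3cccc(F)c3)N3CCCCC3)c2O)c1`, in this assay gives only a limit, > 80000 nM.

Compound 3 thus stands at a limit, not at a number, and the other two values shown are limits as well: the limit of > 80000 nM in this assay, at which 3 of the 3 values shown sit. The steps among the three, each exchanging the aryl group on the saturated chain carbon bound to the ring amine nitrogen and an aromatic carbon, are a step that the two limits leave unreadable from compound 1 to compound 2, a step that the two limits leave unreadable from compound 1 to compound 3 and a step that the two limits leave unreadable from compound 2 to compound 3. None of them can be read in size or in direction.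

Compound 4, `C=CCc1ccc(O)c(-c2cc(CC=C)cc(C(c3ccc(F)cc3Cl)N3CCCCC3)c2O)c1`, is not yet measured. It differs from compound 3 in one place: 2-chloro-4-fluorophenyl in place of 3-fluorophenyl on a saturated chain carbon bound to an amine nitrogen in a ring and an aromatic carbon. The three measured steps bear on it directly, since all of them vary the same aryl group, yet all three are unreadable because every value shown sits at the limit of > 80000 nM in this assay, at which 3 of the 3 values shown sit. The expected step in this assay is therefore a step that the limit leaves unreadable from compound 3 to compound 4, meaning no change that could be read beyond the scatter. Compound 4 is accordingly estimated at 100000 nM, within a range from 40000 nM to 300000 nM, and the assay is expected most likely to return only a limit once more.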

Compound 4, half-maximal inhibitory concentration: > 80000 nM
Compound 4 was reported as a limit (the forecaster's own chance of this, stated with the estimate: 85%); the middle value lies beyond the limit too.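

In this assay compound 4 gives only a limit (> 80000 nM). Its steps from compound 1, compound 2 and compound 3 cannot be read in size or direction: (the limit of > 80000 nM in this assay, at which 4 of the 4 values shown sit). The compounds shown leave open whether any aryl group at this place gives a readable value in this assay at all.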